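The source may report more compounds than this note shows. Statements on the series, on what has been measured and on what is new or still open speak of the compounds shown alone.

Measured compounds in an assay for inhibition of methylcytosine dioxygenase TET2 (Homo sapiens), read by mass spectrometry, with stated times of 30 min and 1 h; a higher number here means a weaker inhibitor, a lower number a stronger inhibitor:

Compound 1 `CCCCCOS(=O)(=O)c1ccc(F)c2ncc(I)cc12`: compound 1 gives > 200000 nM, which is a limit of the assay.
Compound 2 `NS(=O)(=O)c1ccc(F)c2ncc(I)cc12`: compound 2 gives 86600 nM.
Compound 3 `CNS(=O)(=O)c1ccc(F)c2ncc(I)cc12`: compound 3 gives > 200000 nM, which is a limit of the assay.

Compound 3 therefore stands at the upper edge of what this assay reports, with no number of its own; only compound 2 has one, and two of the three values sit at the limit (the limit of > 200000 nM in this assay, at which 2 of the 3 values shown sit). Replacing the sulfonyl substituent moved the series within this narrow span: an at least 2.3-fold lower number from compound 1 to compound 2 (0.36 log units; beyond the scatter), then an at least 2.3-fold higher number from compound 2 to compound 3 (0.36 log units; beyond the scatter), the step from compound 1 to compound 3 being unreadable between the two limits.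

Compound 4 `O=S(=O)(NCc1ccccc1)c1ccc(F)c2ncc(I)cc12` differs from compound 3 by phenyl in place of hydrogen on a saturated chain carbon bound to a sulfonamide nitrogen; cut one bond further out, the same difference reads methyl to benzyl. The step that bears on it is an at least 2.3-fold higher number from compound 2 to compound 3 (0.36 log units; beyond the scatter), where growth on the sulfonamide nitrogen already pushed the value to the limit. A further enlargement at the same nitrogen is expected to give no step beyond the scatter from the limit, a step that the limit leaves unreadable from compound 3 to compound 4. Compound 4 is thus expected at 300000 nM, within 100000 nM to 1000000 nM, most probably reported only as a limit.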

Compound 4, half-maximal inhibitory concentration: > 200000 nM
Compound 4 ended at the assay's limit (the forecaster's own chance of this, stated with the estimate: 80%); the middle value lies beyond the limit too.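

Benzyl in place of hydrogen on the sulfonamide nitrogen gives an at least 2.3-fold higher number from compound 2 to compound 4 (0.36 log units; beyond the scatter), so compound 2 remains the only compound with a number of its own in this assay. Methyl and benzyl on this nitrogen both leave the value at a limit, and adding phenyl to the chain carbon restores no readable value. The steps between two limits cannot be read, so methyl and benzyl cannot be ordered, and the series offers only one numerical value: the limit of > 200000 nM in this assay, at which 3 of the 4 values shown sit.

From the compounds shown here alone, whether any group on this nitrogen can match or improve on compound 2 stays open, for example a hydroxyethyl chain or a chain ending in a carboxylic acid. Only the sulfonyl substituent varies among these compounds, leaving the contribution of the shared core open.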